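Aryl urea tail variation on the quinoline-amine series

The source may hold more compounds than are shown below. What is called first, only, known or untested is meant among the compounds shown, and "the series" means these compounds.

Measured so far:
compound 1 `COc1cc(NC(C)CCCNC(=O)NNC(=O)Nc2ccc(F)cc2)c2ncccc2c1` — >= 250000 nM
compound 2 `COc1cc(NC(C)CCCNC(=O)Nc2cccc(C(F)(F)F)c2)c2ncccc2c1` — 20000 nM

Compound 1 sits at the limit of a functional assay on MOLT-4 cells (Homo sapiens) for inhibition, read by MTT assay, with a stated time of 72 h; on this read-out lower numbers stand for stronger inhibition and higher numbers for weaker inhibition; its value of >= 250000 nM is a limit of the assay and not a number (the limit of >= 250000 nM in this assay, at which 1 of the 2 values shown sits). Compound 2 reaches 20000 nM in this assay. Among the compounds with values here, the only measured step is an at least 12-fold lower number from compound 1 to compound 2 (1.09 log units; beyond the scatter), and it concerns a different change from the one considered here.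

Compound 3 `COc1cc(NC(C)CCCNC(=O)NNC(=O)Nc2cccc(Cl)c2)c2ncccc2c1` is not yet measured. It differs from compound 1 by 3-chlorophenyl in place of 4-fluorophenyl on an amide-type nitrogen. Within the data shown here, this alteration touches only the outer aryl group of the same tail, while the step from compound 1 to compound 2 swapped the entire ((4-fluorophenyl)carbamoyl)amino unit for a 3-(trifluoromethyl)phenyl group; no measured step therefore bears on the change from compound 1 to compound 3. With compound 1 at the limit, the expectation for compound 3 is a step of an at least 1.2-fold lower number from compound 1 to compound 3 (0.09 log units; that floor lies within the scatter), that is no movement beyond the scatter, with a real chance that this assay again reports only a limit. Compound 3 is accordingly estimated at 200000 nM, in the range 60000 nM to 500000 nM.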

Compound 3, half-maximal inhibitory concentration: 93000 nM
For compound 3 the middle estimate is 2.2-fold (0.33 log units) above the measured one; measured number inside the range.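

Exchanging 4-fluorophenyl for 3-chlorophenyl on the amide-type nitrogen, with the rest of the tail unchanged, gives an at least 2.6-fold lower number from compound 1 to compound 3 (0.42 log units; beyond the scatter), so the outer aryl group of this tail does register in this assay. The longer tail now also has a real number to set against the 3-(trifluoromethyl)phenyl urea, and that comparison gives a 4.7-fold higher number from compound 2 to compound 3 (0.67 log units; beyond the scatter), so the tail of compound 2 still holds the lower number, although the gap is now a measured size and not a floor. Compound 1 remains a limit and not a number, so the first step gives a minimum size only: the limit of >= 250000 nM in this assay, at which 1 of the 3 values shown sits.

The step changes the halogen and its place on the ring together, so the compounds shown do not separate these two changes, and 4-chlorophenyl or 3-fluorophenyl on the same tail would be needed to tell them apart. Going by these compounds, it also remains open how this tail responds to 3-(trifluoromethyl)phenyl as its outer aryl group, and whether an amine or a carboxylic acid on that ring would move the number further in either direction.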